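Removing the Cyano Group: From Compound 2 to Compound 3

A few compounds are considered here, and "the series" means these few. Any claim that something is new, unique, unknown or untested is made for them only; others in the source may bear on it.

Measured so far:
- compound 1, `COc1cc(CN(C(=O)Nc2ccc(C)cc2)n2cnnc2)cc(OC)c1OC`: 46800 nM
- compound 2, `Cc1ccsc1CN(C(=O)Nc1cccc(C#N)c1)n1cnnc1`: 28900 nM

Of the compounds shown here, two have been tested in a functional assay on B16-F10 cells (Mus musculus) for cytotoxicity, read by MTT assay, with a stated time of 48 h; on this read-out lower numbers stand for stronger inhibition and higher numbers for weaker inhibition. Compound 1 `COc1cc(CN(C(=O)Nc2ccc(C)cc2)n2cnnc2)cc(OC)c1OC` gives 46800 nM. Compound 2 `Cc1ccsc1CN(C(=O)Nc1cccc(C#N)c1)n1cnnc1` gives 28900 nM in this assay. Both numbers are in the weak range, and the gap between compound 2 and compound 1 lies within the usual scatter of repeated measurements, so nothing separates the two.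

Compound 3 `Cc1ccsc1CN(C(=O)Nc1ccccc1)n1cnnc1` is the next compound to be tested. It differs from compound 2 in one place:

hydrogen in place of cyano on an aromatic carbon

Going by the values given here, no step between measured compounds shows what this change does. With both measured compounds standing close together and weakly active, the expected step of a 1.4-fold higher number from compound 2 to compound 3 (0.14 log units; within the scatter) is small, with a slight lean toward a weaker value. Compound 3 is estimated to give 40000 nM in this assay, with a likely range from 15000 nM to 110000 nM.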

Compound 3, half-maximal inhibitory concentration: 31100 nM
Compound 3: middle estimate off by 1.3-fold (0.11 log units), on the high side; measured number inside the range.
By their numbers in this assay, from the lowest: compounds 2, 3 and 1 (each within the scatter of the next).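

In this assay, going by these compounds alone, swapping 3-cyanophenyl for phenyl gives a 1.1-fold higher number from compound 2 to compound 3 (0.03 log units; within the scatter), which is the first direct comparison at this position. The two compounds cannot be told apart, so in this one pair the nitrile is not needed for the weak cytotoxicity seen in these cells, although a single pair cannot show how other compounds would behave. No supporting measurement is available to explain this result.

On these data alone, it remains open whether any group on this aromatic carbon can move the number beyond the scatter, for example an amine, a carboxylic acid or a methoxy group. Within the data shown here, it is also open whether removing the nitrile would give the same result on a core carrying a different group from the one in compound 2.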